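This account rests on a few compounds, and the source may have more. Where it says the series, first, only, none or still open, it means among the compounds named here.

Measured so far in an ADME assay on Raji cells (Homo sapiens) for cytotoxicity, with a stated time of 72 h; on this read-out higher numbers stand for an effect only at larger amounts of compound and lower numbers for an effect already at smaller amounts:

Compound 1 `O=C(Nc1nc2c(Cl)cccc2s1)c1cc([N+](=O)[O-])ccc1Cl`: 15000 nM
Compound 2 `O=C(Nc1ccc(-c2nc3ccccc3s2)cc1)c1cc([N+](=O)[O-])ccc1Cl`: > 27000 nM

Compound 2 has no exact number, only a limit: the limit of > 27000 nM in this assay, at which 1 of the 2 values shown sits. From the compounds shown here alone, the compound shows no measured effect in this assay up to that limit, so any comparison with it remains open on one side.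

The next compound, compound 3 `O=C(Nc1ccc(-c2ccccc2)cc1)c1cc([N+](=O)[O-])ccc1Cl`, keeps the rest of compound 2 and changes one group: phenyl in place of 1,3-benzothiazol-2-yl on an aromatic carbon. In words, it has phenyl in place of 1,3-benzothiazol-2-yl on an aromatic carbon, para to a large group.

Within the data shown here, no two measured compounds differ in only one place, so no measured step can serve as a guide. Among the measured compounds shown here, the only other number is that of compound 1, at 15000 nM, which also shows an effect only at large amounts. The expected size of an at least 1.0-fold lower number from compound 2 to compound 3 (0.03 log units; that floor lies within the scatter) stays within the usual scatter, with neither direction favoured. It is quite possible that this assay will again report only a limit. Compound 3 is estimated at 25000 nM, with an expected range from 9000 nM to 60000 nM.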

Compound 3, half-maximal effective concentration: > 27000 nM
Compound 3 ended at the assay's limit; the forecaster's own chance of this, stated with the estimate: 55%; at least 1.0-fold (0.03 log units) between middle value and limit.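

In this assay compound 2 and compound 3 both end at a limit rather than an exact number, so no step can be read between them: the limit of > 27000 nM in this assay, at which 2 of the 3 values shown sit.

Left open is whether phenyl in place of 1,3-benzothiazol-2-yl makes any difference to the read-out, and at what amounts, if any, compound 2 and compound 3 would show an effect.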